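Swapping Cyclohexyl for Phenyl on a Carbonyl Carbon

The compounds below may be only part of what the source reports. "The series", "measured", "known", "first", "only" and "open" are said of these compounds alone.

Of the compounds shown here, three built on one shared core have been measured in a physicochemical assay for lipophilicity, read by HPLC, measured as chromatographic lipophilicity, at pH 7.4; a higher number here means a more lipophilic compound, a lower number a more polar compound. Compound 1 `O=C(C1CCCCC1)N1N=CCC1c1ccccc1` gives 5.9, the highest of the three. Compound 3 `O=C(C1CCN(c2ccccn2)CC1)N1N=CC[C@H]1c1ccccc1` comes nearest with 5.1, a gap that lies beyond the usual scatter, and compound 2 `O=C(c1cn[nH]c1)N1CCC(C(=O)N2N=CCC2c2ccccc2)CC1` lies furthest with 2.1. Compound 4 `O=C(c1ccccc1)N1N=CCC1c1ccccc1` has not yet been measured; it differs from compound 1 in a single place: phenyl in place of cyclohexyl on a carbonyl carbon. No measured pair among these three isolates this change, so the expectation rests on the change alone. A moderate fall in this assay, beyond the scatter, is expected, and the expected step is a number 0.70 log units lower from compound 1 to compound 4 (beyond the scatter). Compound 4 is therefore estimated at 5.2, most likely between 4.6 and 5.8.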

Compound 4, distribution coefficient: 4.6
Estimate against measurement, compound 4: 0.60 log units above, and the stated range covers the measured number.
By their numbers in this assay, from the lowest: compound 2; then compound 4; then compound 3; then compound 1.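

The two groups match in heavy atoms and in hydrogen-bond donors and acceptors, and the enclosing ring's aromatic character is what separates them. Even so, in this assay this single change at the carbonyl carbon gives a number 1.30 log units lower from compound 1 to compound 4 (beyond the scatter), a large step. Nothing shown accounts for the size of this step.

Among the compounds shown here, only this one pair isolates the position, so it remains open whether the step would recur on a different core. Where a tert-butyl group or a carboxylic acid would fall on this carbonyl carbon also remains open.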